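Benzyloxy in Place of Azepanyl on the Shared Core

The compounds below may be only part of what the source reports. "The series", "measured", "known", "first", "only" and "open" are said of these compounds alone.

Compound 1 `CC(C(=O)NCc1ccc(C(F)(F)F)cc1N1CCCCCC1)c1ccc(NS(C)(=O)=O)c(F)c1` gives 1.6 nM in an assay on CHO cells for antagonist activity at transient receptor potential cation channel subfamily V member 1 (Homo sapiens), read by FLIPR; on this read-out lower numbers stand for stronger inhibition and higher numbers for weaker inhibition. On that read-out compound 1 stands level with compound 3 `COc1ccc(N2CCN(c3cc(C(F)(F)F)ccc3CNC(=O)C(C)c3ccc(NS(C)(=O)=O)c(F)c3)CC2)cc1`, which gives 1.6 nM, and together they hold the lowest two of three numbers; compound 2 `CC(C(=O)NCc1ccc(C(F)(F)F)cc1N1CCCCCCC1)c1ccc(NS(C)(=O)=O)c(F)c1` gives 2.8 nM, the step being a 1.8-fold higher number from compound 1 to compound 2 (0.24 log units; within the scatter). Compound 4 `CC(C(=O)NCc1ccc(C(F)(F)F)cc1OCc1ccccc1)c1ccc(NS(C)(=O)=O)c(F)c1` differs from compound 1 by benzyloxy in place of azepan-1-yl on an aromatic carbon. No measured step covers this exchange; the one shown, from a seven- to an eight-membered ring, stayed within the scatter, and compound 3 shows that a large group at this position is tolerated. Compound 4 is therefore expected to weaken only modestly, estimated at 5 nM (range 1.5 nM to 20 nM), a step of a 3.1-fold higher number from compound 1 to compound 4 (0.49 log units; beyond the scatter).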

Compound 4, inhibition constant: 0.9 nM
Compound 4: middle estimate off by 5.6-fold (0.74 log units), on the high side; the measured number lies below the stated range.
By their numbers in this assay, from the lowest: compounds 4, 1, 3 and 2 (each within the scatter of the next, the first and the last beyond it).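

In this assay, this position takes benzyloxy, with its six-membered aromatic ring of carbon only, as readily as azepan-1-yl, with a 1.8-fold lower number from compound 1 to compound 4 (0.25 log units; within the scatter) on the shared core. Against the eight-membered ring, the same exchange gives a 3.1-fold lower number from compound 2 to compound 4 (0.49 log units; beyond the scatter) and so opens a modest gap beyond the scatter. Nothing shown here gives a reason for either step.

The compounds shown leave open whether the oxygen link or the aromatic ring accounts for this result. As far as these compounds go, how a phenoxy group, a phenethyl chain or a benzylamino group would fare at this position also remains open.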